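A Methyl Added to the Pendant Phenyl of Compound 1

The compounds below may be only part of what the source reports. "The series", "measured", "known", "first", "only" and "open" are said of these compounds alone.

Within the data shown here, compound 1, with the structure `COc1cc(-n2cnc3ccc(-c4ccccc4)cc32)cc(OC)c1OC`, is the only compound of this set with a numbered result. In a functional assay on SGC-7901 cells (Homo sapiens) for antiproliferative activity, read by MTT assay, with a stated time of 72 h (a higher number here means a weaker inhibitor, a lower number a stronger inhibitor), compound 1 gives 290 nM. Compound 2, with the structure `COc1cc(-c2ccc3ncn(-c4cc(OC)c(OC)c(OC)c4)c3c2)cc(OC)c1OC`, carries the same three-methoxy-bearing ring on a differently arranged core. In this assay compound 2 reaches only a limit, > 10000 nM, and so offers no number to compare. That leaves compound 1 standing alone on the numbers, with the limit of compound 2 beside it as the limit of > 10000 nM in this assay, at which 1 of the 2 values shown sits.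

Compound 3, with the structure `COc1cc(-n2cnc3ccc(-c4ccc(C)cc4)cc32)cc(OC)c1OC`, is not yet measured. It differs from compound 1 by methyl in place of hydrogen on an aromatic carbon, a change placed on an aromatic carbon of a six-membered aromatic ring of carbon only, para to a large group; read one bond further out, phenyl becomes 4-methylphenyl. Among the measured compounds shown here, no step between two measured compounds is available to weigh such a change. The expected step in this assay from compound 1 to compound 3 is a 1.3-fold higher number from compound 1 to compound 3 (0.12 log units; within the scatter), a shift judged to stay within the usual scatter or to lean slightly toward weaker inhibition. The estimate for compound 3 in this assay is therefore 380 nM, expected to lie between 130 nM and 1100 nM.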

Compound 3, half-maximal inhibitory concentration: 200 nM
Estimate against measurement, compound 3: 1.9-fold (0.28 log units) above; the range from low to high includes it.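

In this assay, among these compounds, this is the first step between two measured compounds, and it reads a 1.5-fold lower number from compound 1 to compound 3 (0.16 log units; within the scatter), for methyl in place of hydrogen on an aromatic carbon, para to a large group. Compound 1 alone could not show how this place on the pendant ring answers to a substitution; the pair now shows that phenyl and 4-methylphenyl cannot be told apart in this assay, so a single added carbon at this place is accepted on the shared core. Nothing given here explains this outcome, and a single step within the scatter gives no direction for the change.

As far as these compounds go, what a carboxylic acid, an amine or a longer chain such as butyl would do on this same aromatic carbon remains open, as does whether a group larger than methyl would also leave the number within the scatter. Also open is whether methyl on another carbon of the pendant ring would read the same way, or whether this pair would stay as close in a cell line other than the one shown.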